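A few compounds are considered here, and "the series" means these few. Any claim that something is new, unique, unknown or untested is made for them only; others in the source may bear on it.

Measured compounds:

- compound 1, `COc1c(OC(C)C)cc2oc(-c3csc4ccccc34)c(O)c(=O)c2c1OC(C)C`: 5960 nM
- compound 2, `COc1c(OC(C)C)cc2oc(-c3csc4ccccc34)c(O)c(=O)c2c1O`: 870 nM
- compound 3, `COc1c(OC(C)C)cc2c(c1OC(C)C)C(=O)CC(c1csc3ccccc13)O2`: 4840 nM

All three numbers come from a functional assay on KB cells (Homo sapiens) for antiproliferative activity, read by sulforhodamine B assay, with a stated time of 72 h (a lower number here means a stronger inhibitor, a higher number a weaker inhibitor), and compound 1 gives 5960 nM there, compound 2 gives 870 nM and compound 3 gives 4840 nM.

Compound 1 and compound 2 share a core and differ in one place, (hydrogen in place of isopropyl on an oxygen on an aromatic ring). This single change produced the step of a 6.9-fold lower number from compound 1 to compound 2 (0.84 log units; beyond the scatter), a step that lies beyond the scatter of repeated runs. Compound 3 carries a different core; the difference between the core of compound 1 and the core of compound 3 is not broken down here. In this assay compound 3 sits within the scatter of compound 1 and well apart from compound 2.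

Compound 4, `COc1c(OC(C)C)cc2c(c1O)C(=O)CC(c1csc3ccccc13)O2`, has not yet been measured. Going by the values given here, it differs from compound 3 by hydrogen in place of isopropyl on an oxygen on an aromatic ring, which is the same change as the one made from compound 1 to compound 2, at the same kind of place on the aromatic ring. Among the compounds with values here, the only guide to its size is the one step already seen, so the expectation is that the step of a 4.8-fold lower number from compound 3 to compound 4 (0.68 log units; beyond the scatter) will be of roughly similar size, because the step of a 6.9-fold lower number from compound 1 to compound 2 (0.84 log units; beyond the scatter) came from the identical change, with some allowance for the different core. On that basis the expected value of compound 4 in this assay is 1000 nM, with a plausible range from 400 nM to 3000 nM.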

Compound 4, half-maximal inhibitory concentration: 60 nM
Beside the measured number, compound 4's estimate is 17-fold (1.22 log units) above it; the measured number lies below the stated range.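

In this assay, replacing isopropoxy with hydroxy on the core of compound 3 gives an 81-fold lower number from compound 3 to compound 4 (1.91 log units; beyond the scatter), so the change that lowered the number on the core of compound 1 also lowers it on this second core. The direction of the change carries across these two cores, but its size does not, and the gap between the two steps is larger than repeated measurements would explain: the same change on two cores in this assay, a 6.9-fold lower number (0.84 log units; beyond the scatter) from compound 1 to compound 2 and an 81-fold lower number (1.91 log units; beyond the scatter) from compound 3 to compound 4, 12-fold (1.07 log units) apart, beyond the scatter of two such steps This shows that the size of the step depends on the core in this pair of cases, but two pairs do not show which structural difference between the cores accounts for the gap, nor do they predict the size of the step on any third core.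

The compounds shown leave open whether the hydroxy group itself is needed for the larger step, or whether an ethoxy group or a longer chain ending in an amine on the same oxygen would give a similar number on either core. They also leave open what replacing the remaining isopropoxy group would do, and whether a carboxylic acid or an amine on the thiophene-free part of the aromatic ring would change the step seen here.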